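The compounds below may be only part of what the source reports. "The series", "measured", "known", "first", "only" and "open" are said of these compounds alone.

Among the compounds with values here, compound 2, whose structure is `CO[C@H]1O[C@H](CNC(=O)CN(C(C)=O)c2ccccc2)[C@@H](OS(=O)(=O)O)[C@H](OS(=O)(=O)O)[C@@H]1OS(=O)(=O)O`, is one of two compounds measured in an assay on isolated protein for binding affinity to fibroblast growth factor 1 (Homo sapiens), read by surface plasmon resonance; a higher number here means weaker binding, a lower number tighter binding. In this assay compound 2 gives 196000 nM. The other measured compound, compound 1, with structure `CCN(CC(=O)NC[C@H]1O[C@H](OC)[C@@H](OS(=O)(=O)O)[C@@H](OS(=O)(=O)O)[C@@H]1OS(=O)(=O)O)C(=O)CCCCCCCCCOS(=O)(=O)O`, gives 111000 nM in this assay; the gap between the two numbers falls within the usual scatter of the method, so neither compound can be called the tighter binder on this evidence.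

Compound 3, with structure `CCN(CC(=O)NC[C@H]1O[C@H](OC)[C@@H](OS(=O)(=O)O)[C@@H](OS(=O)(=O)O)[C@@H]1OS(=O)(=O)O)C(=O)CCCCC(=O)O`, has not yet been measured in this assay. The change from compound 2 to compound 3 is ((4-carboxybutyl)carbonyl)(ethyl)amino in place of acetyl(phenyl)amino on a saturated chain carbon bound to a carbonyl carbon. Compound 3 shares with compound 1 the ethyl-bearing nitrogen on the chain, so its number is expected to land near the values of compound 1 and compound 2, with a step from compound 2 of a 1.3-fold lower number from compound 2 to compound 3 (0.12 log units; within the scatter) that is expected to stay within the scatter. The estimate for compound 3 in this assay is 150000 nM, with an expected range from 60000 nM to 400000 nM.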

Compound 3, dissociation constant: 160000 nM
Estimate against measurement, compound 3: 1.1-fold (0.03 log units) below, within the range that was stated.
By their numbers in this assay, from the lowest: compounds 1, 3 and 2 (each within the scatter of the next).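

In this assay, putting ((4-carboxybutyl)carbonyl)(ethyl)amino in place of acetyl(phenyl)amino on a saturated chain carbon bound to a carbonyl carbon gives a 1.2-fold lower number from compound 2 to compound 3 (0.09 log units; within the scatter), so this position accepts the loss of the aromatic ring and the arrival of a carboxy-ended chain with no readable change in binding. Changing only the end of the chain, with carboxy in place of 5-(sulfooxy)pentyl, gives a 1.4-fold higher number from compound 1 to compound 3 (0.16 log units; within the scatter), so the carboxy end and the sulfooxy-bearing end cannot be told apart here either. Nothing else shown accounts for this flat picture.

Going by these compounds, what remains open is whether any group at this position can move binding beyond the scatter. A primary amine at the chain end, or a longer chain ending in carboxy, would test this.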